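From 3-chlorophenyl to 4-chlorophenyl on an amide-type nitrogen

The compounds below may be only part of what the source reports. "The series", "measured", "known", "first", "only" and "open" are said of these compounds alone.

Compounds measured so far:
Compound 1 `CN(C(=O)C1(c2ccccc2)CCCC1)c1ccccc1Cl` gives 23000 nM
Compound 2 `CN(C(=O)C1(c2ccccc2)CCCC1)c1cccc(Cl)c1` gives 17000 nM

Both values come from an ADME assay on MDCK cells (Canis lupus familiaris) for cytotoxicity (on this read-out lower numbers stand for higher toxicity in this test and higher numbers for lower toxicity in this test), and lie within the scatter of each other, so compound 2 holds no separate place from compound 1 on these numbers. Compound 3 `CN(C(=O)C1(c2ccccc2)CCCC1)c1ccc(Cl)cc1` has not yet been measured there. It carries 4-chlorophenyl in place of 3-chlorophenyl on an amide-type nitrogen and otherwise matches compound 2. Within the data shown here, only one measured step bears on this change: a 1.4-fold lower number from compound 1 to compound 2 (0.13 log units; within the scatter) put 3-chlorophenyl in place of 2-chlorophenyl on the same nitrogen and stayed within the scatter. Among the measured compounds shown here, no measured compound yet carries 4-chlorophenyl, so the data offer no direct evidence on it. Resting on compound 2 at 17000 nM and on that single small step, no shift beyond the scatter is expected in this assay and no direction is favoured. The expected step is a 1.1-fold higher number from compound 2 to compound 3 (0.02 log units; within the scatter) by this estimate. Compound 3 is estimated at 18000 nM with a range from 9000 nM to 36000 nM for repeat measurements.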

Compound 3, half-maximal cytotoxic concentration: 20000 nM
Beside the measured number, compound 3's estimate is 1.1-fold (0.05 log units) below it; the measured number falls inside the stated range.
By their numbers in this assay, from the lowest: compounds 2, 3 and 1 (each within the scatter of the next).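

Reading the three compounds together, this assay now has a number for each of 2-chlorophenyl, 3-chlorophenyl and 4-chlorophenyl on the amide-type nitrogen, while the rest of the structure stays the same. The new compound gives a 1.2-fold higher number from compound 2 to compound 3 (0.07 log units; within the scatter) and also a 1.2-fold lower number from compound 1 to compound 3 (0.06 log units; within the scatter) so that, with the earlier step between compound 1 and compound 2 also inside the scatter, none of the three chlorophenyl groups stands apart from the others on this read-out. Nothing on hand gives a reason for this result.

These three compounds do not show whether the same holds once the chlorine gives way to another group on that ring, such as a methoxy group, a carboxylic acid or a primary amine, or once the chlorophenyl group on the nitrogen gives way to an unsubstituted phenyl or a pyridyl group. They also leave open whether a change elsewhere in the shared core, such as a longer chain in place of the methyl group on the same nitrogen, would move the number beyond the scatter in this assay.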